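One Change at a Hydroxyl Group

A few compounds are considered here, and "the series" means these few. Any claim that something is new, unique, unknown or untested is made for them only; others in the source may bear on it.

All three measured compounds were tested in a functional assay on A-375 cells (Homo sapiens), read by thymidine incorporation; on this read-out lower numbers stand for stronger inhibition and higher numbers for weaker inhibition. Compound 1 `C=CCCC(=O)N[C@H]1[C@@H](OCCc2ccccc2)O[C@H](CO)[C@@H](O)[C@@H]1O` is the starting point of the step followed here. In this assay compound 1 gives only a limit, > 50 uM, so its potency is not pinned down to a number. Compound 2 `CCCCCCCCCCCCCCCCO[C@H]1O[C@H](COCC(O)CO)[C@@H](O)[C@H](O)[C@H]1NC(=O)CCCC` gives 3 uM in this assay. Compound 3 `CCCCCCCCO[C@H]1O[C@H](CO)[C@@H](O)[C@H](O)[C@H]1NC(=O)c1ccccc1` likewise returns only a limit in this assay, > 50 uM. Compound 1 therefore sits at the limit of > 50 uM in this assay, at which 2 of the 3 values shown sit, in the company of compound 3, while compound 2 alone yields a measurable number. Going by the values given here, no two of these three compounds differ in just one place, so no single structural step has been measured among them.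

Compound 4 `C=CCCC(=O)N[C@H]1[C@@H](OCCc2ccccc2)O[C@H](CO)[C@@H](O)[C@@H]1OS(=O)(=O)O` is obtained from compound 1 by one change: sulfo in place of hydrogen on an oxygen on a saturated carbon. Among the compounds with values here, no measured step shows what such a change does in this assay, and compound 1 itself offers only a limit as the starting value. The step from compound 1 to compound 4 is therefore expected to be small, a number no higher from compound 1 to compound 4 (the limit leaves the size open), with no clear direction beyond the usual scatter. Compound 4 is accordingly estimated at 50 uM, within a range from 10 uM to 200 uM, and it may well again return only a limit.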

Compound 4, concentration for 50% inhibition: > 50 uM
Compound 4: a limit, no number (the forecaster's own chance of this, stated with the estimate: 70%); the middle value sits exactly at the limit.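

In this assay compound 4 gives > 50 uM, which is a limit and not a number. Going by these compounds alone, compound 1 gives > 50 uM, also only a limit, so no step between compound 1 and compound 4 can be read. What sulfo in place of hydrogen on an oxygen on a saturated carbon does to inhibition stays open, with most compounds shown sharing one limit: the limit of > 50 uM in this assay, at which 3 of the 4 values shown sit.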